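The source may report more compounds than this note shows. Statements on the series, on what has been measured and on what is new or still open speak of the compounds shown alone.

Compound 1 `O=C(Nc1ccccc1)c1cnc(NCc2c(F)ccc3c2CCO3)n2cnnc12` is set against compound 4 `O=C1CC2(CC2)CN1c1cnc(NCc2c(F)ccc3c2CCO3)n2cnnc12`, which has not yet been measured. Among the compounds with values here, in a physicochemical assay for lipophilicity, using the shake flask method, in phosphate buffer, measured as octanol-water partition, with a stated time of 30 min, at pH 7.4 (on this read-out higher numbers stand for higher lipophilicity and lower numbers for lower lipophilicity), compound 1 gives 4.1, the highest of the three numbers measured so far; compound 2 `O=C1CCCN1c1cnc(NCc2c(F)ccc3c2CCO3)c2cn[nH]c(=O)c12` gives 1.8 and compound 3 `Cc1ncccc1-c1cnc(NCc2c(F)ccc3c2CCO3)c2cn[nH]c(=O)c12` gives 3, both beyond the scatter below compound 1. Compound 4 differs from compound 1 in one place: a group of 8 heavy atoms (6 carbon, 1 nitrogen, 1 oxygen; one three-membered non-aromatic ring of carbon only, one five-membered non-aromatic ring with 1 hetero atom) in place of a group of 9 heavy atoms (7 carbon, 1 nitrogen, 1 oxygen; one six-membered aromatic ring of carbon only), on an aromatic carbon. Within the data shown here, one measured step bears on this change. On the core of compound 2, a number 1.20 log units higher from compound 2 to compound 3 (beyond the scatter), a large step when 2-methylpyridin-3-yl stands in place of 2-oxopyrrolidin-1-yl on an aromatic carbon. The change from compound 1 to compound 4 runs the other way, from phenylcarbamoyl to a five-membered non-aromatic ring with one hetero atom carrying a three-membered ring, so a large step downward, beyond the scatter, is expected in this assay. Compound 4 is therefore expected to give 2.9, between 2.3 and 3.5, an estimated step of a number 1.20 log units lower from compound 1 to compound 4 (beyond the scatter).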

Compound 4, distribution coefficient: 1.9
For compound 4 the middle estimate is 1.00 log units above the measured one; measured number outside the range, below it.
By their numbers in this assay, from the lowest: compounds 2 and 4 (each within the scatter of the next); then compound 3; then compound 1.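

Within the data shown here, the first step on the core of compound 1 shows that, in this assay, this aromatic carbon responds strongly to its substituent: a number 2.20 log units lower from compound 1 to compound 4 (beyond the scatter). Among these compounds, the only earlier step at a substituted aromatic carbon came from the core of compound 2, so this result extends a large change to a second core and to a different pair of groups. No measurement given here explains the drop.

Going by these compounds, the exchange replaces the six-membered aromatic ring, removes the hydrogen-bond donor and adds the three-membered ring all at once, so the share of each remains open. On these data alone, how far the number would move with a cyclohexylcarbamoyl group or a simple dimethylamino group at this aromatic carbon on the core of compound 1 also remains open.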